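Swapping methylsulfanyl for benzyl(methyl)amino on the shared core

The source may hold more compounds than are shown below. What is called first, only, known or untested is meant among the compounds shown, and "the series" means these compounds.

In a functional assay on HL-60 cells (Homo sapiens) for inhibition, read by XTT assay, with a stated time of 72 h (a higher number here means a weaker inhibitor, a lower number a stronger inhibitor), compound 3 (`CSCc1ncnc2c1ncn2[C@@H]1O[C@H](CO)[C@@H](O)[C@H]1O`) gives 5000 nM and stands second highest of three numbers, with compound 1 (`[N-]=[N+]=NCc1ncnc2c1ncn2[C@@H]1O[C@H](CO)[C@@H](O)[C@H]1O`) lowest at 780 nM and compound 2 (`OC[C@H]1O[C@@H](n2cnc3c(CSCc4ccccc4)ncnc32)[C@H](O)[C@@H]1O`) highest at 19200 nM in this series. Compound 4 (`CN(Cc1ccccc1)Cc1ncnc2c1ncn2[C@@H]1O[C@H](CO)[C@@H](O)[C@H]1O`) has benzyl(methyl)amino in place of methylsulfanyl on a saturated chain carbon bound to an aromatic carbon. Going by the values given here, no measured compound carries benzyl(methyl)amino, so the evidence is indirect. The closest guide is the removal of phenyl (a 3.8-fold lower number from compound 2 to compound 3 (0.58 log units; beyond the scatter)), while replacing azido gave (a 6.4-fold higher number from compound 1 to compound 3 (0.81 log units; beyond the scatter)) with methylsulfanyl and (a 25-fold higher number from compound 1 to compound 2 (1.39 log units; beyond the scatter)) with benzylsulfanyl. A modest step towards a higher number is therefore expected in this assay (a 2.4-fold higher number from compound 3 to compound 4 (0.38 log units; beyond the scatter)). For compound 4 the estimate is 12000 nM, with an expected range of 3000 nM to 50000 nM in this assay.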

Compound 4, half-maximal inhibitory concentration: 2400 nM
Compound 4: the middle estimate sits 5.0-fold (0.70 log units) above what was measured; measured number below the stated range.
By their numbers in this assay, from the lowest: compound 1; then compound 4; then compound 3; then compound 2.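

In this assay, a phenyl-bearing group on this saturated chain carbon need not raise the number: benzyl(methyl)amino gives a 2.1-fold lower number from compound 3 to compound 4 (0.32 log units; beyond the scatter) against methylsulfanyl and an 8.0-fold lower number from compound 2 to compound 4 (0.90 log units; beyond the scatter) against benzylsulfanyl. Azido keeps the lowest number of the series, as a 3.1-fold higher number from compound 1 to compound 4 (0.49 log units; beyond the scatter) shows. Nothing available explains why the amine lowers the number relative to either sulfanyl group.

From the compounds shown here alone, it remains open whether the nitrogen, its methyl or its benzyl accounts for the drop. Benzylamino, dimethylamino or a piperidine ring on the same carbon would separate these parts.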